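Fimbrolide analogues: acetylation of the hydroxy compound

The source may report more compounds than this note shows. Statements on the series, on what has been measured and on what is new or still open speak of the compounds shown alone.

Measured so far:
compound 1 `CCC[C@@H](OC(C)=O)C1=C(Br)/C(=C/Br)OC1=O` 1 ug/mL
compound 2 `CCC[C@@H](O)C1=C(Br)/C(=C/I)OC1=O` 0.3 ug/mL

In a functional assay on KB cells (Homo sapiens) for cytotoxicity (a higher number here means that more compound is needed for the effect, a lower number that less compound is needed), compound 2 gives 0.3 ug/mL, the lowest of the two numbers; compound 1 gives 1 ug/mL, a higher number that lies beyond the scatter. Compound 1 and compound 2 differ in two places, so no single step can be read between them.

Compound 3 `CCC[C@@H](OC(C)=O)C1=C(Br)/C(=C/I)OC1=O` carries acetyl in place of hydrogen on an oxygen on a saturated carbon. Within the data shown here, no measured pair isolates this change. Compound 3 is expected to give 0.5 ug/mL, a step of a 1.7-fold higher number from compound 2 to compound 3 (0.22 log units; within the scatter) that is estimated to stay close to the scatter, leaning toward the higher number of compound 1; the range is 0.15 ug/mL to 1.5 ug/mL.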

Compound 3, concentration for half-maximal effect: 0.2 ug/mL
The estimate for compound 3 lay 2.5-fold (0.40 log units) above the measured number; low and high end bracket the measured number.
By their numbers in this assay, from the lowest: compounds 3 and 2 (each within the scatter of the next); then compound 1.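

In this assay hydroxy to acetoxy reads a 1.5-fold lower number from compound 2 to compound 3 (0.18 log units; within the scatter) and so acetyl in place of hydrogen on this oxygen is tolerated with the iodo compounds. Among these compounds, with the acetoxy group held, iodo in place of bromo on the double-bonded chain carbon reads a 5.0-fold lower number from compound 1 to compound 3 (0.70 log units; beyond the scatter) and is the only single-place step here beyond the scatter. Nothing at hand explains either step.

From the compounds shown here alone, whether acetylation behaves alike in the bromo compounds stays open. So does the outcome with a longer acyl chain, a methyl ether or an amine at this saturated carbon.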